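The source may hold more compounds than are shown below. What is called first, only, known or untested is meant among the compounds shown, and "the series" means these compounds.

- Compound 1 `Cn1ccc2c(Oc3ccc(NC(=O)c4cc5cccnc5n(-c5ccccc5)c4=O)cc3)ncnc21`: 88400 nM
- Compound 2 `COc1ccc(-n2c(=O)c(C(=O)Nc3ccc(Oc4ncnc5c4ccn5C)cc3)cc3cccnc32)cc1`: 105000 nM

In a functional assay on MCF7 cells (Homo sapiens) for cytotoxicity, read by MTT assay, with a stated time of 72 h (a lower number here means a stronger inhibitor, a higher number a weaker inhibitor), compound 1 gives 88400 nM, within the scatter of compound 2 at 105000 nM. Compound 3 `Cn1ccc2c(Oc3ccc(NC(=O)c4cc5cccnc5n(-c5ccc(C(F)(F)F)c(Cl)c5)c4=O)cc3)ncnc21` has 3-chloro-4-(trifluoromethyl)phenyl in place of phenyl on an aromatic nitrogen. Among the compounds with values here, the only measured step bearing on this phenyl is a 1.2-fold higher number from compound 1 to compound 2 (0.07 log units; within the scatter), with methoxy in place of hydrogen on an aromatic carbon. This single small step offers no support for a large shift, so no change beyond the scatter is expected in this assay, though with wide uncertainty. The expected step is a 1.3-fold lower number from compound 1 to compound 3 (0.10 log units; within the scatter). For compound 3 the estimated value is 70000 nM, with an expected range from 20000 nM to 150000 nM.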

Compound 3, half-maximal inhibitory concentration: "not active" (no number reported)
Nothing numeric was reported for compound 3; no gap can be computed for the estimate.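

Within the data shown here, compound 3 is reported as "not active" without a number in this assay, so no step from compound 1 to compound 3 can be read. Nothing shown explains this result. The compounds shown leave open how far 3-chloro-4-(trifluoromethyl)phenyl in place of phenyl shifts the number.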